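Compound 3 to compound 4: amine change on the chain

The source may hold more compounds than are shown below. What is called first, only, known or untested is meant among the compounds shown, and "the series" means these compounds.

Measured so far:
- compound 3 `CN1CCN(CCCOc2c(OCc3ccccc3)cc(O)c3c(=O)cc(-c4ccccc4)oc23)CC1` gives 3760 nM in a functional assay on B16 cells (Mus musculus) for cytotoxicity, read by MTT assay, with a stated time of 72 h; on this read-out higher numbers stand for weaker inhibition and lower numbers for stronger inhibition
- compound 1 `COc1c(OCCCCN2CCN(C)CC2)cc(O)c2c(=O)cc(-c3ccc(F)cc3Br)oc12` gives 3440 nM in this assay
- compound 2 `COc1c(OCCCCN2CCN(C)CC2)cc(O)c2c(=O)cc(-c3cccc(F)c3)oc12` gives 4520 nM in this assay

Compound 3 holds the second highest of the three numbers, with compound 1 and compound 2 both within the scatter of it, so the three stand level. Going by the values given here, the one measured step, a 1.3-fold higher number from compound 1 to compound 2 (0.12 log units; within the scatter), concerns the aryl ring and is within the scatter; it does not touch the amine end of the chain.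

Compound 4 `O=c1cc(-c2ccccc2)oc2c(OCCCCN3CCCC3)c(OCc3ccccc3)cc(O)c12` differs from compound 3 by (pyrrolidin-1-yl)methyl in place of 4-methylpiperazin-1-yl on a saturated chain carbon, three bonds along the chain from an oxygen on an aromatic ring. Among the compounds with values here, no measured step bears on this change, and the three values give no ground to expect movement. The step from compound 3 to compound 4 in this assay is therefore expected to stay within the scatter, a 1.0-fold lower number from compound 3 to compound 4 (0.02 log units; within the scatter). Compound 4 is estimated at 3600 nM, range 1500 nM to 8500 nM.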

Compound 4, half-maximal inhibitory concentration: 3210 nM
Compound 4: the middle estimate sits 1.1-fold (0.05 log units) above what was measured, and the stated range covers the measured number.
By their numbers in this assay, from the lowest: compounds 4, 1, 3 and 2 (each within the scatter of the next).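

In this assay, going by these compounds alone, the first step at the amine end of the chain, 4-(pyrrolidin-1-yl)butyl in place of 3-(4-methylpiperazin-1-yl)propyl, gives a 1.2-fold lower number from compound 3 to compound 4 (0.07 log units; within the scatter), so this position takes a change of both amine ring and chain length with no movement beyond the scatter. No supporting data bear on this result.

Because ring and chain length change together, their separate contributions stay unresolved; 3-(pyrrolidin-1-yl)propyl on the core of compound 4 would isolate the chain length. From the compounds shown here alone, how a morpholine or a primary amine at the chain end would read also remains open.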